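The compounds below may be only part of what the source reports. "The series", "measured", "known", "first", "only" and "open" are said of these compounds alone.

Working notes on the series, step from compound 3 to compound 4. In a functional assay on the whole organism (strain Kunming) with Mus musculus as the target, with a stated time of 0.5 h (on this read-out higher numbers stand for an effect only at larger amounts of compound and lower numbers for an effect already at smaller amounts), compound 3 `COc1cccc(/C=C/C(=O)OC/C=C/c2cc(OC)c(OC)cc2OC)c1` gives 249 mg/kg, and compound 2 `COc1cc(OC)c(OC)cc1/C=C/COC(=O)/C=C/c1ccccc1Cl` gives 248 mg/kg. These two cannot be told apart, as a 1.0-fold higher number from compound 2 to compound 3 (0.00 log units; within the scatter) shows. Compound 1 `COc1cc(OC)c(OC)cc1/C=C/COC(=O)/C=C/c1ccc(OC)c(OC)c1` gives > 300 mg/kg, which is a limit and not a number.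

Compound 4 `COc1ccc(/C=C/C(=O)OC/C=C/c2cc(OC)c(OC)cc2OC)cc1` has 4-methoxyphenyl in place of 3-methoxyphenyl on a double-bonded chain carbon bound to a double-bonded chain carbon.

Going by the values given here, three measured steps bear on this change. The closest is a 1.0-fold higher number from compound 2 to compound 3 (0.00 log units; within the scatter), which exchanges the group at the same place and leaves the reading unmoved. The other two start from the limit of compound 1 and so give only floors: an at least 1.2-fold lower number from compound 1 to compound 2 (0.08 log units; that floor lies within the scatter) and an at least 1.2-fold lower number from compound 1 to compound 3 (0.08 log units; that floor lies within the scatter). None of the three is shown to lie beyond the scatter, although the true size of the two floor steps is unknown. No step beyond the scatter is therefore expected in this assay, and no direction can be assigned. The expected result is a 1.0-fold higher number from compound 3 to compound 4 (0.00 log units; within the scatter). For compound 4 the estimated value is 250 mg/kg, with an expected range from 140 mg/kg to 400 mg/kg.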

Compound 4, dose for half-maximal effect: > 300 mg/kg
Compound 4 was reported as a limit; the forecaster's own chance of this, stated with the estimate: 30%; at least 1.2-fold (0.07 log units) between middle value and limit.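

In this assay, compound 3 and compound 4 have the same atoms joined differently, so 4-methoxyphenyl in place of 3-methoxyphenyl is the first change shown here that leaves the atoms of the group as they were. The result is an at least 1.2-fold higher number from compound 3 to compound 4 (0.08 log units; that floor lies within the scatter), and the comparison with the chlorinated compound gives an at least 1.2-fold higher number from compound 2 to compound 4 (0.08 log units; that floor lies within the scatter); each is only a floor, so neither establishes a real difference, though a larger true step is not excluded. The step joining compound 1 and compound 4 cannot be read, and the limit now marks the upper end of the readings for this series: the limit of > 300 mg/kg in this assay, at which 2 of the 4 values shown sit.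

As far as these compounds go, whether 4-methoxyphenyl truly differs from 3-methoxyphenyl at this place in this assay remains open, as does the true size of the step from 2-chlorophenyl. Also open, from the compounds shown here alone, is what a 4-dimethylaminophenyl or 4-carboxyphenyl group would give on this double-bonded chain carbon, with the rest of compound 3 unchanged.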